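The compounds below may be only part of what the source reports. "The series", "measured", "known", "first", "only" and "open" are said of these compounds alone.

Values in a functional assay on PC-3 cells (Homo sapiens) for antiproliferative activity, read by MTT assay, with a stated time of 72 h (on this read-out lower numbers stand for stronger inhibition and higher numbers for weaker inhibition), for the three measured compounds:

Compound 1 `C/C=C/C(=O)Nc1cc2c(N3CCc4ccccc43)ncnc2cc1O[C@@H]1CCOC1` gives 5220 nM.
Compound 2 `CCN(CC)C/C=C/C(=O)Nc1cc2c(N3CCc4ccccc43)ncnc2cc1O[C@@H]1CCOC1` gives 5780 nM.
Compound 3 `O=C(/C=C/CN1CCCCC1)Nc1cc2c(N3CCc4ccccc43)ncnc2cc1O[C@@H]1CCOC1` gives 4510 nM.

Compound 3 has the lowest of the three numbers, but its step to compound 1 and its step to compound 2 are both within the scatter, so no order among the three can be read from them. The three steps, a 1.1-fold higher number from compound 1 to compound 2 (0.04 log units; within the scatter), a 1.2-fold lower number from compound 1 to compound 3 (0.06 log units; within the scatter) and a 1.3-fold lower number from compound 2 to compound 3 (0.11 log units; within the scatter), all concern the group on the saturated chain carbon bound to a double-bonded chain carbon, and none of them moved the number beyond the scatter.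

Compound 4 `O=C(/C=C/CN1CCC(CO)CC1)Nc1cc2c(N3CCc4ccccc43)ncnc2cc1O[C@@H]1CCOC1` differs from compound 3 in a single place: hydroxymethyl in place of hydrogen on a saturated ring carbon. For the measured compounds named here, no measured step changes a substituent on that ring, so the closest guide is that exchanging the whole amine group left the numbers essentially unchanged, as in a 1.3-fold lower number from compound 2 to compound 3 (0.11 log units; within the scatter). On that basis the expectation for compound 4 in this assay is a step of about a 1.0-fold lower number from compound 3 to compound 4 (0.00 log units; within the scatter), which is no step beyond the scatter. Compound 4 is therefore estimated at 4500 nM, with a range from 2200 nM to 9500 nM.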

Compound 4, half-maximal inhibitory concentration: 3310 nM
Beside the measured number, compound 4's estimate is 1.4-fold (0.13 log units) above it; the range from low to high includes it.
By their numbers in this assay, from the lowest: compounds 4, 3, 1 and 2 (each within the scatter of the next).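

In this assay, hydroxymethyl on a saturated ring carbon, three ring bonds from the ring nitrogen, gives a 1.4-fold lower number from compound 3 to compound 4 (0.13 log units; within the scatter). For the compounds shown here, this is the first measured change on the ring of the piperidin-1-yl group rather than an exchange of the whole amine group, and it shows that this ring carbon can carry a group with a hydrogen-bond donor and acceptor without the number leaving the scatter. The comparisons with the other two compounds agree, with a 1.7-fold lower number from compound 2 to compound 4 (0.24 log units; within the scatter) and a 1.6-fold lower number from compound 1 to compound 4 (0.20 log units; within the scatter), so the 4-(hydroxymethyl)piperidin-1-yl group sets compound 4 apart from neither; no measurement here bears on the reason for this outcome.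

With every step within the scatter, these compounds leave open whether any group on this ring carbon can move the number beyond it, for example a carboxylic acid, a primary amine or a longer chain such as 2-hydroxyethyl. They also leave open whether hydroxymethyl would behave the same way on another carbon of this ring, or whether a morpholine ring in place of the piperidine ring would change the picture.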